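A few compounds are considered here, and "the series" means these few. Any claim that something is new, unique, unknown or untested is made for them only; others in the source may bear on it.

Compound 1 `Cn1c(-c2ccccc2)cnc1NC(=O)c1ccccc1`: in a toxicity assay on THP-1 cells (Homo sapiens) for inhibition (a higher number here means that more compound is tolerated, a lower number that less compound is tolerated), compound 1 reaches the limit > 100000 nM.
Compound 2 `COc1ccc(-c2cnc(NC(=O)c3cccc(OC)c3)n2C)cc1`: in this assay compound 2 reaches the limit > 100000 nM.
Compound 3 `COc1ccc(-c2cnc(NC(=O)c3ccccc3)n2C)cc1`: in this assay compound 3 reaches the limit > 100000 nM.

Compound 1 stands at a limit, not a number, and the same holds for every value shown here: the limit of > 100000 nM in this assay, at which 3 of the 3 values shown sit. Compound 4 `Cc1cccc(C(=O)Nc2ncc(-c3ccccc3)n2C)c1` differs from compound 1 by methyl in place of hydrogen on an aromatic carbon. The two measured steps, a step that the two limits leave unreadable from compound 1 to compound 3 and a step that the two limits leave unreadable from compound 2 to compound 3, cannot be read in size, so no direction can be drawn from them. The expectation for compound 4 is therefore simply that it stays at the limit, with a number no higher from compound 1 to compound 4 (the limit leaves the size open) not separable from no change. The estimate for compound 4 is 100000 nM, ranging from 50000 nM to 300000 nM.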

Compound 4, half-maximal cytotoxic concentration: > 50000 nM
Compound 4: only a limit was reported (the forecaster's own chance of this, stated with the estimate: 85%); the middle value lies beyond the limit too.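

The step between compound 1 and compound 4 cannot be read: both values are limits, not numbers. The compounds shown leave open where any of them would give an actual number in this assay.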